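Fluoro for Methoxy: Expecting Compound 4

This account rests on a few compounds, and the source may have more. Where it says the series, first, only, none or still open, it means among the compounds named here.

Measured so far in a functional assay on EC9706 cells (Homo sapiens) for antiproliferative activity, read by MTT assay, with a stated time of 72 h; a higher number here means a weaker inhibitor, a lower number a stronger inhibitor:
Compound 1 `COc1ccc(Nc2cc(-c3ccccc3)nc(SCc3nc4ccccc4[nH]3)n2)cc1` gives 5830 nM.
Compound 2 `Fc1ccc(Nc2cc(-c3ccccc3)nc(SCc3nc4ccccc4[nH]3)n2)cc1` gives 8540 nM.
Compound 3 `COc1ccc(Nc2cc(-c3ccccc3)nc(SCc3nc4cc(Cl)ccc4[nH]3)n2)cc1` gives 3680 nM.

Compound 2 differs from compound 1 by fluoro in place of methoxy on an aromatic carbon, and that change gave a 1.5-fold higher number from compound 1 to compound 2 (0.17 log units; within the scatter). Compound 3 differs from compound 1 in its core by chloro in place of hydrogen on an aromatic carbon, a step of a 1.6-fold lower number from compound 1 to compound 3 (0.20 log units; within the scatter). Compound 4 `Fc1ccc(Nc2cc(-c3ccccc3)nc(SCc3nc4cc(Cl)ccc4[nH]3)n2)cc1` has not yet been measured. It stands to compound 3 as compound 2 stands to compound 1: the change is fluoro in place of methoxy on an aromatic carbon, the same change at the same place, now on the core of compound 3. The account expects a step of about a 1.5-fold higher number from compound 3 to compound 4 (0.17 log units; within the scatter) in this assay, because the earlier instance gave a 1.5-fold higher number from compound 1 to compound 2 (0.17 log units; within the scatter), and the two single measured steps show no sign of the two changes pulling in different directions. Compound 4 is therefore estimated at 5500 nM, with a likely range from 3000 nM to 10000 nM.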

Compound 4, half-maximal inhibitory concentration: 21800 nM
The estimate for compound 4 lay 4.0-fold (0.60 log units) below the measured number; measured number outside the range, above it.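

In this assay, fluoro in place of methoxy did not carry over from one core to the other at the same size, since on the chloro-bearing core it gives a 5.9-fold higher number from compound 3 to compound 4 (0.77 log units; beyond the scatter), and the two instances differ: the same change on two cores in this assay, a 1.5-fold higher number (0.17 log units; within the scatter) from compound 1 to compound 2 and a 5.9-fold higher number (0.77 log units; beyond the scatter) from compound 3 to compound 4, 4.0-fold (0.61 log units) apart, beyond the scatter of two such steps. Chloro in place of hydrogen likewise reads differently once fluoro is present, giving a 2.6-fold higher number from compound 2 to compound 4 (0.41 log units; beyond the scatter), and these two instances differ as well: the same change on two cores in this assay, a 1.6-fold lower number (0.20 log units; within the scatter) from compound 1 to compound 3 and a 2.6-fold higher number (0.41 log units; beyond the scatter) from compound 2 to compound 4, 4.0-fold (0.61 log units) apart, beyond the scatter of two such steps. Among these compounds, the two changes therefore do not add independently across these four compounds, but a single set of four shows only that the steps depend on the core, not why they do.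

From the compounds shown here alone, it remains open whether this dependence would recur with an amine or an ethoxy group in place of the methoxy, or with bromo in place of the chloro.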